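The source may hold more compounds than are shown below. What is called first, only, known or untested is meant among the compounds shown, and "the series" means these compounds.

Measured compounds in an ADME assay on J774.1 cells (Mus musculus) for cytotoxicity, read by MTT assay, with a stated time of 48 h; a higher number here means a weaker inhibitor, a lower number a stronger inhibitor:
- compound 1 `Cc1c(C(=O)N/N=C/c2ccc(C(F)(F)F)cc2)no[n+]1[O-]` gives > 400000 nM, which is a limit of the assay and not a number.
- compound 2 `Cc1c(C(=O)N/N=C/c2ccc(N(C)C)cc2)no[n+]1[O-]` gives 129000 nM, a number.

Within the data shown here, compound 2 is thus the only compound with a number here, and the one measured step, an at least 3.1-fold lower number from compound 1 to compound 2 (0.49 log units; beyond the scatter), runs toward it, with the starting point resting at the limit of > 400000 nM in this assay, at which 1 of the 2 values shown sits.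

Compound 3 `Cc1c(C(=O)N/N=C/c2ccc(Br)cc2)no[n+]1[O-]` differs from compound 2 by bromo in place of dimethylamino on an aromatic carbon. Among the measured compounds shown here, this change removes the dimethylamino whose entry marked the only step seen, so the one bearing step is an at least 3.1-fold lower number from compound 1 to compound 2 (0.49 log units; beyond the scatter), read in the opposite sense: the group that left in that step returns here in kind, and the number is expected to move back up toward the limit, though bromo is not trifluoromethyl and the limit hides the full size of the earlier step. For compound 3 the step expected is a 2.3-fold higher number from compound 2 to compound 3 (0.37 log units; beyond the scatter), giving an estimate of 300000 nM, with a range from 110000 nM to 800000 nM.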

Compound 3, half-maximal inhibitory concentration: 162000 nM
The estimate for compound 3 lay 1.9-fold (0.27 log units) above the measured number; the measured number falls inside the stated range.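

In this assay, the step is a 1.3-fold higher number from compound 2 to compound 3 (0.10 log units; within the scatter), so at this position, para to a large group, the compounds shown do not separate bromo from dimethylamino. The earlier lowering therefore does not belong to dimethylamino alone, since bromo in place of trifluoromethyl gives an at least 2.4-fold lower number from compound 1 to compound 3 (0.39 log units; beyond the scatter), which leaves compound 1, with trifluoromethyl, apart from compound 2 and compound 3. Compound 1 gives > 400000 nM, which is a limit of the assay and not a number.

The full size of both steps from compound 1 stays open because that end of each rests on a limit: the limit of > 400000 nM in this assay, at which 1 of the 3 values shown sits.

Also open, from the compounds shown here alone, is whether the low reading extends to other groups at this position on the shared core, such as a nitrile, a carboxylic acid or a methoxy group, or whether any of them moves toward compound 1.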